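The source may report more compounds than this note shows. Statements on the series, on what has been measured and on what is new or still open speak of the compounds shown alone.

Compound 2 `Cc1oc2ncnc(Nc3ccc(OCc4cccc(F)c4)c(Cl)c3)c2c1C(=O)O` carries a free acid on the shared core and in a functional assay on A549 cells (Homo sapiens) for cytotoxicity, read by MTT assay, with a stated time of 72 h (a higher number here means a weaker inhibitor, a lower number a stronger inhibitor), compound 2 gives 21400 nM. Compound 1 `CCOC(=O)c1c(C)oc2ncnc(Nc3ccc(OCc4cccc(F)c4)c(Cl)c3)c12` is its ethyl ester; compound 1 gives 500 nM, so the step of a 43-fold lower number from compound 2 to compound 1 (1.63 log units; beyond the scatter) is large, the change being (ethyl in place of hydrogen on an oxygen next to a carbonyl group). Compound 3 `Cc1oc2ncnc(Nc3cccc(Cl)c3)c2c1C(=O)O` differs from compound 2 by hydrogen in place of (3-fluorobenzyl)oxy on an aromatic carbon, and compound 3 gives 95500 nM, a step of a 4.5-fold higher number from compound 2 to compound 3 (0.65 log units; beyond the scatter). Compound 4 `CCOC(=O)c1c(C)oc2ncnc(Nc3cccc(Cl)c3)c12` is the unmeasured ethyl ester of compound 3; the change ethyl in place of hydrogen on an oxygen next to a carbonyl group is the same as that from compound 2 to compound 1, at the same place. Because the earlier step of a 43-fold lower number from compound 2 to compound 1 (1.63 log units; beyond the scatter) was large, a step of similar size is expected here, though the smaller core of compound 3 adds uncertainty. The expected step is a 32-fold lower number from compound 3 to compound 4 (1.50 log units; beyond the scatter), giving an estimate for compound 4 of 3000 nM, between 800 nM and 15000 nM.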

Compound 4, half-maximal inhibitory concentration: > 1000000 nM
Compound 4: no number, only a limit; the forecaster's own chance of this, stated with the estimate: 5%; middle value at least 330-fold (2.52 log units) from the limit.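

In this assay compound 4 gives > 1000000 nM, which is a limit of the assay and not a number. The ethyl change gives an at least 10-fold higher number from compound 3 to compound 4 (1.01 log units; beyond the scatter), and the loss of (3-fluorobenzyl)oxy gives an at least 2000-fold higher number from compound 1 to compound 4 (3.30 log units; beyond the scatter), so the ethyl change does not carry from one core to the other and its effect here depends on the core: the same change on two cores in this assay, a 43-fold lower number (1.63 log units; beyond the scatter) from compound 2 to compound 1 and an at least 10-fold higher number (1.01 log units; beyond the scatter) from compound 3 to compound 4, at least 440-fold (2.65 log units) apart, beyond the scatter of two such steps This shows that the two changes do not act independently across these four compounds, but it does not show why, nor how large the true gap is, since one end of it is only a limit: the same change on two cores in this assay, a 4.5-fold higher number (0.65 log units; beyond the scatter) from compound 2 to compound 3 and an at least 2000-fold higher number (3.30 log units; beyond the scatter) from compound 1 to compound 4, at least 440-fold (2.65 log units) apart, beyond the scatter of two such steps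

As far as these compounds go, it remains open whether a methyl ester or an amide in place of the ethyl ester would follow compound 1 or compound 4. From the compounds shown here alone, whether the same reversal appears on any other core also remains open.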